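Three Inactive Amides and an Untested Fluoro Analogue

The source may hold more compounds than are shown below. What is called first, only, known or untested is meant among the compounds shown, and "the series" means these compounds.

Measured compounds:
compound 1 `C/C(=C\c1cc(-c2ccc(C)cc2)co1)C(N)=O`: > 50000 nM
compound 2 `C/C(=C\c1cc(-c2ccc(F)cc2)co1)C(N)=O`: > 50000 nM
compound 3 `C/C(=C\c1ccc(-c2ccc(C)cc2)o1)C(N)=O`: > 50000 nM

In a functional assay on BGC-823 cells (Homo sapiens) for cytotoxicity, read by CCK-8 assay, with a stated time of 24 h (a higher number here means a weaker inhibitor, a lower number a stronger inhibitor), compound 1 gives only a limit, > 50000 nM, not a number. Compound 2 likewise gives a limit, > 50000 nM. Compound 3 also gives a limit, > 50000 nM. The change from compound 1 to compound 2 is fluoro in place of methyl on an aromatic carbon, and a step that the two limits leave unreadable from compound 1 to compound 2 because of the limit of > 50000 nM in this assay, at which 3 of the 3 values shown sit. The difference between the core of compound 1 and the core of compound 3 is not broken down here. Compound 4 `C/C(=C\c1ccc(-c2ccc(F)cc2)o1)C(N)=O` is not yet measured; it differs from compound 3 by fluoro in place of methyl on an aromatic carbon, the same change as that from compound 1 to compound 2. Since that earlier change stayed at the limit, compound 4 is expected to remain at the limit as well, so that the expected step that the limit leaves unreadable from compound 3 to compound 4 is small. Compound 4 is estimated at 60000 nM in this assay.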

Compound 4, half-maximal inhibitory concentration: 940 nM
For compound 4 the middle estimate is 64-fold (1.81 log units) above the measured one; the measured number lies below the stated range.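

In this assay, fluoro in place of methyl on an aromatic carbon gives an at least 53-fold lower number from compound 3 to compound 4 (1.72 log units; beyond the scatter), a large effect on the core of compound 3. The value of compound 3, > 50000 nM, is a limit and not a number, so this step gives only the smallest size the change can have. The change therefore cannot be said either to carry over between the two cores or to fail to, because the step from compound 1 to compound 2 cannot be read: the limit of > 50000 nM in this assay, at which 3 of the 4 values shown sit.

As far as these compounds go, it remains open whether chloro, methoxy or an amine at that place would behave as fluoro does on either core. From the compounds shown here alone, it also remains open whether the value of compound 4, 940 nM, would survive replacing the amide with a carboxylic acid.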